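Cytotoxicity notes: oxolane in place of thiophene on the amide

The source may hold more compounds than are shown below. What is called first, only, known or untested is meant among the compounds shown, and "the series" means these compounds.

Measured so far:
- compound 1, `O=C(Nc1ncc(Cc2ccc(F)cc2)s1)C1CCCCC1`, gives in an ADME assay on HepG2 2.2.15 cells (Homo sapiens) for cytotoxicity (a lower number here means that less compound is tolerated, a higher number that more compound is tolerated), the entry > 50000 nM.
- compound 2, `O=C(Nc1ncc(C(Oc2ccc3cc(Br)ccc3c2)c2ccc(Cl)cc2)s1)c1cccs1`, gives in this assay the entry "not toxic" (no number reported).
- compound 3, `O=C(Nc1ncc(C(OCc2ccc(Cl)cc2)c2ccccc2)s1)c1cccs1`, gives in this assay the entry "not toxic" (no number reported).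

The entry for compound 1 is a limit of the assay, not a number; it sits at the limit of > 50000 nM in this assay, at which 1 of the 3 values shown sits. Compound 2 stands without a single number: its entry is a verbal report only, as is that of compound 3, and the single numeric entry in the set is itself a limit. Compound 4, `O=C(Nc1ncc(C(Oc2ccc3cc(Br)ccc3c2)c2ccc(Cl)cc2)s1)C1CCCO1`, differs from compound 2 in one place: oxolan-2-yl in place of thiophen-2-yl on a carbonyl carbon. For the measured compounds named here, no step between measured compounds exists, so no measured size is known for a change of this kind; in this assay the expectation for compound 4 is no shift beyond the usual scatter. Compound 4 is expected to give about 60000 nM, between 20000 nM and 200000 nM, most likely reported only as a limit.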

Compound 4, half-maximal cytotoxic concentration: "not toxic" (no number reported)
The entry for compound 4 holds no number; the estimate stays without a comparison.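

Compound 2 and compound 4 are both reported in this assay only as "not toxic", and no step can be read between them. The compounds shown leave open any actual cytotoxic concentration, as the sole numeric entry, that of compound 1, is a limit: the limit of > 50000 nM in this assay, at which 1 of the 4 values shown sits.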